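The compounds below may be only part of what the source reports. "The series", "measured", "known", "first", "only" and "open" are said of these compounds alone.

Three compounds have been measured so far in an ADME assay on L02 cells (Homo sapiens) for cytotoxicity, read by MTT assay, with a stated time of 24 h; a lower number here means a stronger inhibitor, a higher number a weaker inhibitor:

- compound 1 (`CN1C/C(=C\c2ccc(C(F)(F)F)cc2)C(=O)/C(=C/c2ccccc2F)C1`) gives 18600 nM in this test
- compound 2 (`CN1C/C(=C\c2ccc(C#N)cc2)C(=O)/C(=C/c2ccccc2F)C1`) gives 11000 nM in this test
- compound 3 (`COc1cc(/C=C2\CN(C)C/C(=C\c3ccc(F)cc3)C2=O)cc(OC)c1`) gives 21900 nM in this test

Compound 3 at 21900 nM lies within the scatter of both compound 1 and compound 2, so the three values cannot be ranked. Compound 4 (`COc1cc(/C=C2\CN(C)C/C(=C\c3ccc(C#N)cc3)C2=O)cc(OC)c1`) has not yet been measured. It differs from compound 3 by cyano in place of fluoro on an aromatic carbon, para to a large group (cyano in place of fluoro on an aromatic carbon). Within the data shown here, the only measured step that brings in cyano is a 1.7-fold lower number from compound 1 to compound 2 (0.23 log units; within the scatter) and it lies within the scatter. Among the measured compounds shown here, that step replaces trifluoromethyl rather than fluoro, and no step that replaces fluoro has been measured, so it is only a loose guide. No change beyond the scatter is therefore expected in this assay, only a possible small drift towards a lower number. The expected 1.5-fold lower number from compound 3 to compound 4 (0.16 log units; within the scatter) stays within the scatter. The estimated value for compound 4 is 15000 nM (expected range 7000 nM to 30000 nM).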

Compound 4, half-maximal inhibitory concentration: 14000 nM
Beside the measured number, compound 4's estimate is 1.1-fold (0.03 log units) above it; low and high end bracket the measured number.
By their numbers in this assay, from the lowest: compounds 2, 4, 1 and 3 (each within the scatter of the next).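

In this assay, the change from fluoro to cyano on the aromatic carbon gives a 1.6-fold lower number from compound 3 to compound 4 (0.19 log units; within the scatter), so this replacement also stays inside the scatter. Taken with a 1.7-fold lower number from compound 1 to compound 2 (0.23 log units; within the scatter), where cyano replaced trifluoromethyl in compounds with a different second aromatic substituent, it shows that both measured steps to cyano at this position leave each pair unresolved, with no compound going against this. No measurement bearing on the reason for this result is available.

Going by these compounds, the four compounds carry only fluoro, cyano or trifluoromethyl at this position, so the effect on the number of an amine or a carboxylic acid there remains open. Also open, on these data alone, is whether a longer chain at this position would give a step beyond the scatter.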